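Replacing the group on the carbonyl of compound 1

The source may report more compounds than this note shows. Statements on the series, on what has been measured and on what is new or still open speak of the compounds shown alone.

Measured so far in a physicochemical assay for solubility, in phosphate buffer, measured as kinetic solubility, at pH 7.4; on this read-out higher numbers stand for higher solubility and lower numbers for lower solubility:
- Compound 1 `Cc1ccccc1-c1nc(CN2CCC(C(=O)NCCCN3CCCCC3)CC2)c(C)o1`: > 65 ug/mL (a limit)
- Compound 2 `Cc1ccccc1-c1nc(CN2CCC(C(=O)NCCCN3CCCC(CC(C)C)C3)CC2)c(C)o1`: 54.9 ug/mL
- Compound 3 `Cc1ccccc1-c1nc(CN2CCC(C(=O)NCCCCN3C[C@H](C)C[C@H](C)C3)CC2)c(C)o1`: > 71 ug/mL (a limit)

For compound 1, the result of > 65 ug/mL is a limit and not a number. Compound 4 `Cc1ccccc1-c1nc(CN2CCC(C(=O)N3CCN(CCN(C)C)CC3)CC2)c(C)o1` keeps the core of compound 1 but exchanges the group on the carbonyl carbon: 4-(2-(dimethylamino)ethyl)piperazin-1-yl in place of (3-(piperidin-1-yl)propyl)amino on a carbonyl carbon.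

For the measured compounds named here, no measured compound carries the entering group, so the evidence is indirect. Changes within the leaving group give an at least 1.1-fold lower number from compound 1 to compound 2 (0.07 log units; that floor lies within the scatter) and an at least 1.2-fold higher number from compound 2 to compound 3 (0.11 log units; that floor lies within the scatter), while the remaining comparison gives a step that the two limits leave unreadable from compound 1 to compound 3. None of these steps replaces the whole group, so they are only a rough guide. Going by the two readable floors, from compound 1 to compound 2 and from compound 2 to compound 3, no step beyond the scatter is expected in this assay. The expected step is a step that the limit leaves unreadable from compound 1 to compound 4. For compound 4 the estimated value is 68 ug/mL, with an expected range from 40 ug/mL to 95 ug/mL.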

Compound 4, solubility: > 67 ug/mL
Compound 4: only a limit was reported (the forecaster's own chance of this, stated with the estimate: 65%); the middle value lies beyond the limit too.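

Compound 1 and compound 4 both have only a limit, not a number, in this assay, so the step between them cannot be read. The compounds shown leave open whether exchanging the group on the carbonyl carbon changes the read-out in this assay at all, and by how much.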